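The source may report more compounds than this note shows. Statements on the series, on what has been measured and on what is new or still open speak of the compounds shown alone.

Values so far in a functional assay on HEK-293T cells (Homo sapiens) for cytotoxicity, read by MTT assay (a lower number here means that less compound is tolerated, a higher number that more compound is tolerated), for the series:
compound 1 `COc1cc(Nc2c(-c3ccc(F)cc3)nc3cnccn23)cc(OC)c1OC` gives 36000 nM
compound 2 `COc1ccc(Nc2c(-c3ccc(OC)cc3)nc3ccccn23)cc1` gives 34000 nM
compound 3 `COc1ccc(Nc2c(-c3cccc(B(O)O)c3)nc3ccccn23)cc1` gives 48000 nM

Compound 3 at 48000 nM lies within the scatter of both other compounds, so these three values cannot be ranked. Next is compound 4 `COc1ccc(Nc2c(-c3cccc(O)c3)nc3ccccn23)cc1` and its difference from compound 3 is one oxygen atom in place of a group of 3 heavy atoms (1 boron, 2 oxygen; no ring), on an aromatic carbon on an aromatic carbon of a six-membered aromatic ring of carbon only, meta to a large group.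

Among the compounds with values here, one measured step bears on this ring, and it is a 1.4-fold higher number from compound 2 to compound 3 (0.15 log units; within the scatter) with the whole substituted ring exchanged. That step stays within the scatter, so replacing the substituent on this ring has not yet shifted this assay in any measured pair. Within the data shown here, compound 1 differs from compound 3 in more than one place and supplies no clean step. The data hold no direct comparison for a hydroxy group, so this expectation rests on a single step. No shift beyond the scatter is expected, and the estimated change is a 1.2-fold lower number from compound 3 to compound 4 (0.08 log units; within the scatter) in either direction. For compound 4 the estimated value is 40000 nM with an expected range of 20000 nM to 80000 nM in this read-out.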

Compound 4, concentration lethal to 50% of the cells: 47000 nM
The estimate for compound 4 lay 1.2-fold (0.07 log units) below the measured number; the range from low to high includes it.
By their numbers in this assay, from the lowest: compounds 2, 1, 4 and 3 (each within the scatter of the next).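

In this assay, within the data shown here, this is the first step that changes only the substituent and keeps the surrounding ring in place: hydroxy replaces the boron-bearing group on an aromatic carbon of the six-membered aromatic ring, meta to a large group, and the result is a 1.0-fold lower number from compound 3 to compound 4 (0.01 log units; within the scatter). The wider exchange of 4-methoxyphenyl for 3-hydroxyphenyl gives a 1.4-fold higher number from compound 2 to compound 4 (0.14 log units; within the scatter), so both the small substituent swap and the exchange of the whole substituted ring stay within the scatter, and this read-out does not separate hydroxy from the boron-bearing group at this place. No available evidence gives a reason for these values.

From the compounds shown here alone, whether an amine or a carboxylic acid at this same place would also stay within the scatter remains open, as does the outcome for a longer chain there. Going by these compounds, it is also open whether changing the methoxy group on the other aromatic ring of compound 3 and compound 4, while this position stays fixed, would produce any step beyond the scatter in this assay.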